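Swapping chloro for methoxy on the benzyl arm

A few compounds are considered here, and "the series" means these few. Any claim that something is new, unique, unknown or untested is made for them only; others in the source may bear on it.

Compound 3, with the structure `COC(=O)C1C(=O)C(C(=O)OC)[C@H](c2cccc([N+](=O)[O-])c2)N(Cc2ccc(Cl)cc2)[C@@H]1c1cccc([N+](=O)[O-])c1`, has been tested in an ADME assay on J774.1 cells (Mus musculus) for cytotoxicity, with a stated time of 48 h (on this read-out lower numbers stand for an effect already at smaller amounts and higher numbers for an effect only at larger amounts of compound), and gives 46.6 uM. Among the compounds with values here, this is the highest of the two numbers measured so far, and the nearest is compound 1, `COC(=O)C1=C(O)C[C@H](c2ccccn2)N(Cc2ccc(OC)cc2)[C@@H]1c1ccccn1`, which gives 29.9 uM; the gap between compound 3 and compound 1 lies within the scatter. Compound 2, `COC(=O)C1C(=O)C(C(=O)OC)[C@H](c2cccc([N+](=O)[O-])c2)N(Cc2ccccc2)[C@@H]1c1cccc([N+](=O)[O-])c1`, reaches only the limit of the assay in this assay, reported as > 100 uM, which is a limit and not a number.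

Compound 4, `COC(=O)C1C(=O)C(C(=O)OC)[C@H](c2cccc([N+](=O)[O-])c2)N(Cc2ccc(OC)cc2)[C@@H]1c1cccc([N+](=O)[O-])c1`, has not yet been measured. It differs from compound 3 at one place: methoxy in place of chloro on an aromatic carbon. Within the data shown here, the only measured step, chloro in place of hydrogen, gave an at least 2.1-fold lower number from compound 2 to compound 3 (0.33 log units; beyond the scatter), but it bears on this question only loosely, since methoxy in place of chloro is a different exchange and neither value of that pair is a direct model for methoxy. Compound 1 carries a methoxy group on the same benzyl arm but on a different core, so it offers no clean comparison. The step from compound 3 to compound 4 is therefore expected to stay within the scatter, a 1.0-fold lower number from compound 3 to compound 4 (0.02 log units; within the scatter), and for compound 4 an estimate of 45 uM is given, with a range from 20 uM to 100 uM.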

Compound 4, concentration for half-maximal effect: > 100 uM
Compound 4: no number, only a limit (the forecaster's own chance of this, stated with the estimate: 20%); middle value at least 2.2-fold (0.34 log units) away from the limit.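

Within the shared core, the group on this aromatic carbon clearly matters: replacing 4-chlorobenzyl with 4-methoxybenzyl gives an at least 2.1-fold higher number from compound 3 to compound 4 (0.33 log units; beyond the scatter) in this assay. Compound 4 gives > 100 uM, which is a limit of the assay and not a number. Within the data shown here, until now, the only step at this position showed chloro in place of hydrogen lowering the number, but among compound 2, compound 3 and compound 4 only the chloro compound now gives a measured value, so simply placing a group here does not by itself bring the value within the range of the assay.

The step between compound 2 and compound 4 cannot be read, and how far apart these two really lie stays unknown, because both rest on a limit and not on a number: the limit of > 100 uM in this assay, at which 2 of the 4 values shown sit.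

The compounds shown also leave open whether the effect belongs to chloro alone or would also appear with another group at this place, such as bromo, an amine or a carboxylic acid.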